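Swapping Fluoro for Methoxy on the Same Aromatic Carbon

This account rests on a few compounds, and the source may have more. Where it says the series, first, only, none or still open, it means among the compounds named here.

Among the measured compounds shown here, compound 2 `Cc1c(CC(=O)O)c2ccccc2n1C(=O)c1ccc(OC[C@@H]2CN(C)c3ccccc3O2)c(F)c1` has the higher of the two numbers measured so far in an assay on CHO cells for displacement of a labelled ligand from prostaglandin D2 receptor (Mus musculus), read by scintillation counting, with a stated time of 20 min (on this read-out lower numbers stand for stronger inhibition and higher numbers for weaker inhibition), where compound 2 gives 240 nM. Its parent compound 1 `Cc1c(CC(=O)O)c2ccccc2n1C(=O)c1ccc(OC[C@@H]2CN(C)c3ccccc3O2)cc1` gives 7.7 nM in this assay. For the measured compounds named here, the only measured step, a 31-fold higher number from compound 1 to compound 2 (1.49 log units; beyond the scatter), shows that adding a fluoro group on that aromatic carbon weakens binding strongly. Compound 3 `COc1cc(C(=O)n2c(C)c(CC(=O)O)c3ccccc32)ccc1OC[C@@H]1CN(C)c2ccccc2O1` differs from compound 2 by methoxy in place of fluoro on an aromatic carbon. Going by the values given here, no measured step tests a methoxy group at this position, so the expectation rests on compound 2 alone: a substituent on this carbon has already weakened binding, as seen in a 31-fold higher number from compound 1 to compound 2 (1.49 log units; beyond the scatter), and a methoxy group brings in more heavy atoms than the fluoro it replaces. Compound 3 is therefore expected to show a step of a 1.3-fold higher number from compound 2 to compound 3 (0.10 log units; within the scatter) and an estimated 300 nM, most likely between 60 nM and 1500 nM.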

Compound 3, inhibition constant: 340 nM
Estimate against measurement, compound 3: 1.1-fold (0.05 log units) below; the range from low to high includes it.
By their numbers in this assay, from the lowest: compound 1; then compounds 2 and 3 (each within the scatter of the next).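

Fluoro and methoxy cannot be told apart on this carbon, with a 1.4-fold higher number from compound 2 to compound 3 (0.15 log units; within the scatter) in this assay, even though methoxy has more heavy atoms and carries a hydrogen-bond acceptor. The large loss seen with fluoro is therefore not unique to that group: a second substituent at the same place also gives a large step from the parent, with a 44-fold higher number from compound 1 to compound 3 (1.64 log units; beyond the scatter). No evidence is available on why these two different groups give such similar results.

The compounds shown leave open whether other groups on this carbon, such as chloro, hydroxyl or an amine, would land near compound 2 and compound 3 or near compound 1. They also leave open whether fluoro or methoxy on a different carbon of the same aromatic ring would give a step of similar size.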